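The compounds below may be only part of what the source reports. "The series", "measured", "known", "first", "only" and "open" are said of these compounds alone.

Measured compounds in a functional assay on NCI-H460 cells (Homo sapiens) for antiproliferative activity, with a stated time of 72 h; a lower number here means a stronger inhibitor, a higher number a weaker inhibitor:
compound 1, `CCCCC#Cc1cc([C@@H]2O[C@H](CO)[C@@H](O)[C@H]2O)n2ncnc(N)c12`, 1700 nM
compound 2, `Nc1ncnn2c([C@@H]3O[C@H](CO)[C@@H](O)[C@H]3O)cc(C#Cc3cccs3)c12`, 26600 nM
compound 3, `Nc1ncnn2c([C@@H]3O[C@H](CO)[C@@H](O)[C@H]3O)cc(-c3ccc(Cl)cc3)c12`, 45900 nM

Compound 1 gives the lowest of the three numbers. Its nearest neighbour is compound 2, reached by a 16-fold higher number from compound 1 to compound 2 (1.19 log units; beyond the scatter); compound 3 lies furthest, with a 27-fold higher number from compound 1 to compound 3 (1.43 log units; beyond the scatter). Compounds 2 and 3 are separated by a 1.7-fold higher number from compound 2 to compound 3 (0.24 log units; within the scatter), so the two replacements of hex-1-yn-1-yl land in the same region.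

Compound 4, `Nc1ncnn2c([C@@H]3O[C@H](CO)[C@@H](O)[C@H]3O)cc(-c3ccccc3F)c12`, is not yet measured. Relative to compound 1 the change is 2-fluorophenyl in place of hex-1-yn-1-yl on an aromatic carbon. Among the compounds with values here, the step that bears most on it is the one to compound 3, where 4-chlorophenyl likewise replaced hex-1-yn-1-yl on an aromatic carbon and gave a 27-fold higher number from compound 1 to compound 3 (1.43 log units; beyond the scatter). The step to compound 2, a 16-fold higher number from compound 1 to compound 2 (1.19 log units; beyond the scatter), points the same way. Within the data shown here, both replacements of the hex-1-yn-1-yl chain have so far produced a large rise in this assay; 2-fluorophenyl is a further aryl in the same place, and no measured pair shows how a fluorine-bearing phenyl compares with the 4-chlorophenyl of compound 3. The step into compound 4 is expected to be large and upward, a 24-fold higher number from compound 1 to compound 4 (1.37 log units; beyond the scatter). Compound 4 is expected to give 40000 nM in this assay, with a range of 12000 nM to 130000 nM.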

Compound 4, half-maximal inhibitory concentration: > 100000 nM
Compound 4 ended at the assay's limit; the forecaster's own chance of this, stated with the estimate: 10%; middle value at least 2.5-fold (0.39 log units) away from the limit.
By their numbers in this assay, from the lowest: compound 1; then compounds 2 and 3 (each within the scatter of the next). At a limit, above all of these: compound 4.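

In this assay the value of compound 4, > 100000 nM, is a limit of the assay and not a number: the limit of > 100000 nM in this assay, at which 1 of the 4 values shown sits.

On the aromatic carbon two ring bonds from the ring nitrogen, 2-fluorophenyl in place of hex-1-yn-1-yl gives an at least 58-fold higher number from compound 1 to compound 4 (1.76 log units; beyond the scatter), so this replacement carries the series to the top of the readable range. Compounds 2 and 3 lie within the scatter of each other, yet the replacing group still counts at this place: 2-fluorophenyl in place of 4-chlorophenyl gives an at least 2.1-fold higher number from compound 3 to compound 4 (0.33 log units; beyond the scatter), and 2-fluorophenyl in place of 2-(thiophen-2-yl)ethynyl gives an at least 3.7-fold higher number from compound 2 to compound 4 (0.57 log units; beyond the scatter).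

From the compounds shown here alone, with only these two aryl groups, it remains open whether the halogen, its place on the phenyl ring or its kind separates them, and an unsubstituted phenyl or a 4-fluorophenyl would address that. Going by these compounds, it is also open whether compound 1, at 1700 nM, marks the best of the open-chain groups, or whether a shorter or longer alkynyl chain, or one ending in a hydroxyl or an amine, would move the number further down.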